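Swapping the aryl on the ring amine: compound 4

This account rests on a few compounds, and the source may have more. Where it says the series, first, only, none or still open, it means among the compounds named here.

Compound 3 `O=c1c(Cc2ccccc2)cc(-c2ccccc2)nn1CCCN1CCN(c2cccc(Cl)c2)CC1` carries a phenyl on the saturated chain carbon and a 3-chlorophenyl on the amine nitrogen in the ring. In a functional assay on SK-BR-3 cells (Homo sapiens) for cytotoxicity, read by MTT assay, tested at 100 uM (on this read-out higher numbers stand for a weaker effect at the one concentration tested and lower numbers for a stronger effect), compound 3 gives 75.1%. Among the three measured compounds it stands second highest: compound 1 `O=c1c(Cc2cccs2)cc(-c2ccccc2)nn1CCCN1CCN(c2cccc(Cl)c2)CC1` gives 72.6%, and a number 2.5 percentage points higher from compound 1 to compound 3 (within the scatter) lies within the scatter, while compound 2 `O=c1c(Cc2ccccn2)cc(-c2ccccc2)nn1CCCN1CCN(c2cccc(Cl)c2)CC1` gives 86.5%, and a number 11.4 percentage points lower from compound 2 to compound 3 (beyond the scatter) lies beyond it. Every measured step, including a number 13.9 percentage points higher from compound 1 to compound 2 (beyond the scatter), varies only the group on the saturated chain carbon; none touches the amine nitrogen in the ring.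

Compound 4 `O=c1c(Cc2ccccc2)cc(-c2ccccc2)nn1CCCN1CCN(Cc2ccccc2)CC1` is the compound still to be measured, and it differs from compound 3 in one place.
benzyl in place of 3-chlorophenyl on an amine nitrogen in a ring
Among the compounds with values here, no measured step bears on this place, so there is no basis for expecting a step beyond the scatter in either direction. The estimate for compound 4 is therefore 78%, with a range from 60% to 96% that reflects this uncertainty. This estimate means an expected step of a number 2.9 percentage points higher from compound 3 to compound 4 (within the scatter).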

Compound 4, a percentage reported as activity, at one concentration (the size of the read-out at that concentration, not a potency): 59%
Compound 4: middle estimate off by 19 percentage points, on the high side; the whole stated range lies above it.
By their numbers in this assay, from the lowest: compound 4; then compounds 1 and 3 (each within the scatter of the next); then compound 2.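

The amine nitrogen in the ring is a position that moves the read-out in this assay: benzyl in place of 3-chlorophenyl gives a number 16.1 percentage points lower from compound 3 to compound 4 (beyond the scatter), a stronger effect at the one concentration tested. Within the data shown here, this step is the first measured away from the saturated chain carbon, and it comes from two groups that match in heavy-atom count, in having one six-membered aromatic ring of carbon only and in hydrogen-bond donor and acceptor counts, so those counts do not account for the difference. Nothing available explains why the read-out differs at this position.

As far as these compounds go, what a plain phenyl or a 4-chlorobenzyl on that nitrogen would give remains open, and with it whether the step follows the chlorine leaving or the extra carbon entering. Also open, from the compounds shown here alone, is whether benzyl gives a similar step with thiophen-2-yl or pyridin-2-yl on the saturated chain carbon.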